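The source may report more compounds than this note shows. Statements on the series, on what has been measured and on what is new or still open speak of the compounds shown alone.

Going by the values given here, compound 1 `COc1cc(Oc2cccc(Nc3ccccc3)c2)cc(OC)c1CNCc1ccccc1` is the more potent of the two compounds so far measured in a functional assay on HCT-15 cells (Homo sapiens) for inhibition, read by MTT assay, with a stated time of 72 h; on this read-out lower numbers stand for stronger inhibition and higher numbers for weaker inhibition: compound 1 gives 5020 nM, the lowest of the two numbers, and its nearest neighbour is compound 2 `COc1cc(Oc2cccc(Nc3ccccc3)c2)cc(OC)c1CN(C)C`, which in this assay gives 15600 nM. Among the compounds with values here, the single measured step, a 3.1-fold higher number from compound 1 to compound 2 (0.49 log units; beyond the scatter), shows what follows when benzylamino is exchanged for dimethylamino on the saturated chain carbon bound to an aromatic carbon.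

Compound 3 `COc1cc(Oc2cccc(Nc3ccccc3)c2)cc(OC)c1CNC1CC1` has not been measured. It differs from compound 1 in one place: cyclopropyl in place of benzyl on an amine nitrogen. Read one bond further out, the change is benzylamino to cyclopropylamino, so the six-membered aromatic ring of the benzyl group is again lost, as it was on going to compound 2, while a three-membered non-aromatic ring enters in its stead. Within the data shown here, only the step from compound 1 to compound 2 bears on this, and it was modest and beyond the scatter. For compound 3 a step in the same direction, but of smaller size, is expected, a 1.6-fold higher number from compound 1 to compound 3 (0.20 log units; within the scatter). In this assay compound 3 is therefore estimated at 8000 nM, with a range from 3500 nM to 18000 nM.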

Compound 3, half-maximal inhibitory concentration: 6140 nM
Beside the measured number, compound 3's estimate is 1.3-fold (0.11 log units) above it; the measured number falls inside the stated range.
By their numbers in this assay, from the lowest: compounds 1 and 3 (each within the scatter of the next); then compound 2.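

The aromatic ring of the benzyl group turns out not to be needed for the level seen in this assay: with cyclopropyl on the amine nitrogen in its place, the reading is a 1.2-fold higher number from compound 1 to compound 3 (0.09 log units; within the scatter), so a much smaller three-membered non-aromatic ring serves as well on this read-out. Compound 2 and compound 3 both lack that aromatic ring. Even so, the reading is a 2.5-fold lower number from compound 2 to compound 3 (0.40 log units; beyond the scatter). At this position the two ring-bearing amino groups, benzylamino and cyclopropylamino, thus stand level, and dimethylamino, the only one of the three with two groups on the nitrogen and no hydrogen left on it, stands apart.

Methylamino would help to tell whether the hydrogen on the nitrogen or the ring in the substituent matters more, since it keeps the first and lacks the second. A plain aminomethyl group, cyclohexylamino or phenethylamino would show how far the level of compounds 1 and 3 extends. Nothing available explains these differences.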